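This account rests on a few compounds, and the source may have more. Where it says the series, first, only, none or still open, it means among the compounds named here.

Of the compounds shown here, two of a shared core have been measured in a functional assay on HOP-92 cells (Homo sapiens) for inhibition, read by sulforhodamine B assay, with a stated time of 48 h; on this read-out higher numbers stand for weaker inhibition of growth and lower numbers for stronger inhibition of growth. Compound 1 `COc1ccc(-c2[nH]c3ccccc3c2/C=C(\C#N)S(=O)(=O)c2ccccc2)cc1` gives 2300 nM in this assay. Compound 2 `CC(=O)/C(=C\c1c(-c2ccccc2)[nH]c2ccccc12)S(=O)(=O)c1ccccc1` gives 5900 nM in this assay, the higher of the two numbers, and its gap to compound 1 lies beyond the scatter. Compound 3 `O=C(/C(=C\c1c(-c2ccccc2)[nH]c2ccccc12)S(=O)(=O)c1ccccc1)c1ccccc1` differs from compound 2 in one place: phenyl in place of methyl on a carbonyl carbon, that is, acetyl becomes benzoyl. Among the measured compounds shown here, no measured step of this kind is available, so only a small shift, within the scatter, is expected for the step of a 1.3-fold lower number from compound 2 to compound 3 (0.12 log units; within the scatter). Compound 3 is therefore estimated at 4500 nM, ranging from 1500 nM to 13000 nM.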

Compound 3, concentration for 50% growth inhibition: 5000 nM
Estimate against measurement, compound 3: 1.1-fold (0.05 log units) below; measured number inside the range.
By their numbers in this assay, from the lowest: compound 1; then compounds 3 and 2 (each within the scatter of the next).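

In this assay the change from acetyl to benzoyl gives a 1.2-fold lower number from compound 2 to compound 3 (0.07 log units; within the scatter) and so leaves compound 2 and compound 3 indistinguishable. Among the compounds shown here, this is the first measured step at this position, and it shows that phenyl on the carbonyl carbon, with its six-membered aromatic ring, can stand in place of methyl without a change in the read-out beyond the scatter. Nothing available here offers an explanation for this result.

From the compounds shown here alone, whether a longer chain on this carbonyl carbon would behave in the same way remains open. So does the outcome for an amine or a carboxylic acid there.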